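Changing the Aryl Ring on a Thiourea Tail

The source may report more compounds than this note shows. Statements on the series, on what has been measured and on what is new or still open speak of the compounds shown alone.

Three measured compounds share one core and differ only in the group attached to the ring amine. Compound 1 `NC(=O)c1c(NC(=O)c2ccccc2Cl)sc2c1CCN(Cc1ccccc1Cl)C2` in a functional assay on HeLa cells (Homo sapiens) for antiproliferative activity, with a stated time of 24 h (on this read-out higher numbers stand for weaker inhibition and lower numbers for stronger inhibition), gives 27500 nM. Compound 2 `NC(=O)c1c(NC(=O)c2ccccc2Cl)sc2c1CCN(C(=S)Nc1ccccc1F)C2` gives 28700 nM, and the step of a 1.0-fold higher number from compound 1 to compound 2 (0.02 log units; within the scatter) lies within the scatter. Compound 3 `NC(=O)c1c(NC(=O)c2ccccc2Cl)sc2c1CCN(C(=S)Nc1ccc(C(F)(F)F)cc1)C2` is reported only as the limit > 50000 nM, which is not a number. The step of an at least 1.7-fold higher number from compound 2 to compound 3 (0.24 log units; that floor lies within the scatter) therefore has only a floor, and that floor is within the scatter, as the limit of > 50000 nM in this assay, at which 1 of the 3 values shown sits, shows.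

Compound 4 `NC(=O)c1c(NC(=O)c2ccccc2Cl)sc2c1CCN(C(=S)Nc1c(Cl)cccc1Cl)C2` differs from compound 3 by 2,6-dichlorophenyl in place of 4-(trifluoromethyl)phenyl on an amide-type nitrogen. Among the measured compounds shown here, the one measured step among the thiourea aryl groups, an at least 1.7-fold higher number from compound 2 to compound 3 (0.24 log units; that floor lies within the scatter), was small or unresolved, and no step here moved beyond the scatter, so no large shift is expected in either direction. Compound 4 is estimated at 40000 nM, with a range from 18000 nM to 90000 nM, and the expected step of an at least 1.2-fold lower number from compound 3 to compound 4 (0.09 log units; that floor lies within the scatter) is taken to be small, with a real chance that only a limit is returned.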

Compound 4, half-maximal inhibitory concentration: 26500 nM
Compound 4: middle estimate off by 1.5-fold (0.18 log units), on the high side; measured number inside the range.
By their numbers in this assay, from the lowest: compounds 4, 1 and 2 (each within the scatter of the next). At a limit, above all of these: compound 3.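

The 2,6-dichlorophenyl group on the amide-type nitrogen gives a measured number in this assay, and the step of a 1.1-fold lower number from compound 2 to compound 4 (0.03 log units; within the scatter) shows that replacing 2-fluorophenyl with it leaves the read-out unresolved from that of compound 2. The step of a 1.0-fold lower number from compound 1 to compound 4 (0.02 log units; within the scatter) extends this to the group on the ring amine, so the thiourea tail of compound 4 and the group carried by compound 1 cannot be told apart here. The step of an at least 1.8-fold lower number from compound 3 to compound 4 (0.27 log units; that floor lies within the scatter) has only a floor, and that floor is within the scatter, as compound 3 is reported only as a limit: the limit of > 50000 nM in this assay, at which 1 of the 4 values shown sits.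

As far as these compounds go, it remains open whether any change at this nitrogen can move the number beyond the scatter. A carboxylic acid or an amine in place of the aryl ring, or a longer chain leading to it, would test this.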